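Benzamide in Place of a Lactam on the Shared Core

A few compounds are considered here, and "the series" means these few. Any claim that something is new, unique, unknown or untested is made for them only; others in the source may bear on it.

Of the compounds shown here, two built on a shared core have been measured in an assay for inhibition of inositol hexakisphosphate kinase 3 (Homo sapiens), read by colorimetric assay, coupled enzyme assay and malachite green, with a stated time of 120 min, in the presence of a further agent that is not named here; a higher number here means a weaker inhibitor, a lower number a stronger inhibitor. Compound 1 `O=C(O)c1ccc2noc(-c3ccc(-c4cccnc4)cc3)c2c1` gives 610 nM in this assay. Compound 2 `O=C1CCC(C(=O)Nc2ccc(-c3onc4ccc(C(=O)O)cc34)cc2)CN1` gives 1650 nM, the higher of the two numbers, and its gap to compound 1 lies beyond the usual scatter of this assay.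

Compound 3 `O=C(O)c1ccc2noc(-c3ccc(NC(=O)c4ccccc4)cc3)c2c1` has not yet been measured. It differs from compound 2 in one place: a group of 6 heavy atoms (6 carbon; one six-membered aromatic ring of carbon only) in place of a group of 7 heavy atoms (5 carbon, 1 nitrogen, 1 oxygen; one six-membered non-aromatic ring with 1 hetero atom), on a carbonyl carbon. Put another way, a group of 6 heavy atoms (6 carbon; one six-membered aromatic ring of carbon only) takes the place of a group of 7 heavy atoms (5 carbon, 1 nitrogen, 1 oxygen; one six-membered non-aromatic ring with 1 hetero atom), on a carbonyl carbon whose other neighbours are an amide-type nitrogen. Among the compounds with values here, no step between measured compounds shows how such a swap plays out; the only comparison at hand, compound 1 against compound 2, shows that what sits beyond the shared core can move the number beyond the scatter. The step of a 1.7-fold lower number from compound 2 to compound 3 (0.22 log units; within the scatter) is expected to be modest, leaning toward a lower number without clearly leaving the scatter. For compound 3 the estimate in this assay is 1000 nM, with a range from 400 nM to 3000 nM.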

Compound 3, half-maximal inhibitory concentration: 200 nM
Compound 3: middle estimate off by 5.0-fold (0.70 log units), on the high side; the measured number lies below the stated range.
By their numbers in this assay, from the lowest: compound 3; then compound 1; then compound 2.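

In this assay, within the data shown here, phenyl in place of the six-membered non-aromatic ring, on a carbonyl carbon whose other neighbour is an amide-type nitrogen, produces an 8.3-fold lower number from compound 2 to compound 3 (0.92 log units; beyond the scatter) and so shows that the group at this position can by itself move the number beyond the scatter, which no earlier step could show. Benzamido in place of pyridin-3-yl on an aromatic carbon produces a 3.1-fold lower number from compound 1 to compound 3 (0.48 log units; beyond the scatter) and leaves compound 3 with the lowest number of the three, with its steps to both others printed as beyond the scatter. No measurement at hand bears on what lies behind either step.

The compounds shown leave open whether the ring atoms or the aromatic ring itself account for the step at the carbonyl carbon, a question that a cyclohexyl or a pyridyl group there could address. They also leave open whether a fluorine, a methoxy group or an amine on the phenyl would shift the number further, and whether a methyl group in place of the amide hydrogen would preserve the number of compound 3.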